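This account rests on a few compounds, and the source may have more. Where it says the series, first, only, none or still open, it means among the compounds named here.

Compound 1 `c1ccc2c(-c3cn4ccnc4c(-c4ccc5ncn(C6CCCCC6)c5c4)n3)cccc2c1` gives 2.3% in a functional assay on SK-MEL-2 cells (Homo sapiens) for inhibition, read by sulforhodamine B assay, with a stated time of 48 h, tested at 10 uM (a higher number here means more inhibition at the concentration tested (going by the name of the read-out), a lower number less inhibition), and stands at the lower end of the two numbers measured, with the gap to compound 2 within the scatter. Compound 2 `COc1ccccc1-c1cn2ccnc2c(-c2ccc3ncn(C4CCCCC4)c3c2)n1` gives 12.1% in this assay. Among the measured compounds shown here, the one measured step, a number 9.8 percentage points higher from compound 1 to compound 2 (within the scatter), exchanges the same naphthalen-1-yl for another substituted phenyl and lies within the scatter; it bears directly on the present change. Compound 3 `Fc1ccccc1-c1cn2ccnc2c(-c2ccc3ncn(C4CCCCC4)c3c2)n1` differs from compound 1 by 2-fluorophenyl in place of naphthalen-1-yl on an aromatic carbon. No step beyond the scatter is therefore expected in this assay, the estimated step being a number 5.7 percentage points higher from compound 1 to compound 3 (within the scatter). Compound 3 is estimated at 8%, with a range of -6% to 22%.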

Compound 3, a percentage reported as inhibition, at one concentration (the size of the read-out at that concentration, not a potency): 10.5%
For compound 3 the middle estimate is 2.5 percentage points below the measured one; measured number inside the range.
By their numbers in this assay, from the lowest: compounds 1, 3 and 2 (each within the scatter of the next).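

At this position on the shared core, 2-fluorophenyl in place of naphthalen-1-yl gives a number 8.2 percentage points higher from compound 1 to compound 3 (within the scatter) in this assay and is thus a second single-ring replacement, after the 2-methoxyphenyl of compound 2, with no step beyond the scatter. Fluoro in place of methoxy on an aromatic carbon gives a number 1.6 percentage points lower from compound 2 to compound 3 (within the scatter) and does not separate these two substituents in this read-out. Going by these compounds, whether a carboxylic acid or an amine in place of naphthalen-1-yl would give a step beyond the scatter stays open. No measurement shown offers an explanation for these numbers.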